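Replacing the lactam on a nucleoside side chain

The source may report more compounds than this note shows. Statements on the series, on what has been measured and on what is new or still open speak of the compounds shown alone.

- Compound 1 `OC[C@H]1O[C@@H](n2cnc3c(CSc4ccccn4)ncnc32)[C@H](O)[C@@H]1O`: > 100000 nM, a limit
- Compound 2 `O=C1CCCN1Cc1ncnc2c1ncn2[C@@H]1O[C@H](CO)[C@@H](O)[C@H]1O`: 45000 nM

For the measured compounds named here, in a functional assay on Huh-7 cells (Homo sapiens) for cytotoxicity, read by MTT assay, with a stated time of 3 days (on this read-out lower numbers stand for higher toxicity in this test and higher numbers for lower toxicity in this test), compound 2 gives 45000 nM, the only actual number so far. Compound 1 reads > 100000 nM, and this value is a limit.

Compound 3 `O=C(O)CNCc1ncnc2c1ncn2[C@@H]1O[C@H](CO)[C@@H](O)[C@H]1O` keeps the shared core of compound 2 but carries (carboxymethyl)amino in place of 2-oxopyrrolidin-1-yl on a saturated chain carbon bound to an aromatic carbon.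

Going by the values given here, only one measured step bears on this change, since it alters the same place: an at least 2.2-fold lower number from compound 1 to compound 2 (0.34 log units; beyond the scatter). Its size is bounded on one side only, by the limit of > 100000 nM in this assay, at which 1 of the 2 values shown sits. Among the compounds with values here, no measured compound carries the (carboxymethyl)amino group, so the guide is thin. Going by that single step, a change of similar modest size is expected in this assay, toward a higher number and so toward lower toxicity in this test. A reading that is only a limit would also fit this expectation.

The expected change is a 2.0-fold higher number from compound 2 to compound 3 (0.30 log units; within the scatter).

Compound 3 is estimated at 90000 nM, with an expected range from 30000 nM to 250000 nM.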

Compound 3, half-maximal cytotoxic concentration: > 100000 nM
Compound 3: a limit, no number; the forecaster's own chance of this, stated with the estimate: 55%; at least 1.1-fold (0.04 log units) between middle value and limit.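

In this assay, putting (carboxymethyl)amino in place of 2-oxopyrrolidin-1-yl on a saturated chain carbon bound to an aromatic carbon gives an at least 2.2-fold higher number from compound 2 to compound 3 (0.34 log units; beyond the scatter), a change toward lower toxicity in this test. Compound 3 gives > 100000 nM, which is a limit and not a number. Compound 2 therefore stands as the only one of the three with an actual number, as the compounds carrying (pyridin-2-yl)sulfanyl and (carboxymethyl)amino at this position both read as limits, and the step from compound 1 to compound 3 cannot be read: the limit of > 100000 nM in this assay, at which 2 of the 3 values shown sit.

As far as these compounds go, what remains open is how far compound 1 and compound 3 lie beyond that limit, so the true size of the change at this position and any order between these two compounds are unknown. The compounds shown also do not separate the loss of the ring from the entry of the carboxylic acid, a question that a simple open-chain amine, the methyl ester of the acid or a longer chain ending in a carboxylic acid would bear on.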